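A Second Chloro Added to Compound 2

The source may report more compounds than this note shows. Statements on the series, on what has been measured and on what is new or still open speak of the compounds shown alone.

Of the compounds shown here, three sharing one core have been measured in an assay on mitochondria for inhibition of Amine oxidase [flavin-containing] A (Bos taurus); a lower number here means a stronger inhibitor, a higher number a weaker inhibitor. Compound 1 `Cc1csc(N/N=C/c2ccccc2)n1` gives 7.24 nM. Compound 2 `Cc1csc(N/N=C/c2ccc(Cl)cc2)n1` carries a chloro on an aromatic carbon and gives 38 nM. Compound 3 `Clc1ccc(/C=N/Nc2nc(-c3ccccc3)cs2)cc1` carries phenyl where compound 2 carries methyl; compound 3 gives 100 nM. Among these three numbers compound 2 stands second highest: its nearest neighbour is compound 3 and its furthest is compound 1.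

Compound 4 `Cc1csc(N/N=C/c2ccc(Cl)cc2Cl)n1` has not yet been measured. From compound 2 it differs by chloro in place of hydrogen on an aromatic carbon, the entering chloro sitting ortho to a group of 9 heavy atoms and meta to the chloro already present.

The step that bears most directly on this change is a 5.2-fold higher number from compound 1 to compound 2 (0.72 log units; beyond the scatter), where a chloro likewise entered on an aromatic carbon. The step of a 2.6-fold higher number from compound 2 to compound 3 (0.42 log units; beyond the scatter) concerns a different group at a different place and so bears less. On this basis a modest rise in this assay is expected for compound 4, in the direction seen from compound 1 to compound 2, though a second chloro need not repeat the first. The estimate for compound 4 is 80 nM, within 30 nM to 250 nM. The expected step is a 2.1-fold higher number from compound 2 to compound 4 (0.32 log units; beyond the scatter).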

Compound 4, inhibition constant: 12 nM
For compound 4 the middle estimate is 6.7-fold (0.82 log units) above the measured one; the measured number lies below the stated range.
By their numbers in this assay, from the lowest: compounds 1 and 4 (each within the scatter of the next); then compound 2; then compound 3.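

The second chloro reverses the direction of the first: in this assay, placing chloro on the aromatic carbon ortho to the group of 9 heavy atoms and meta to the chloro already present gives a 3.2-fold lower number from compound 2 to compound 4 (0.50 log units; beyond the scatter), while the earlier replacement of hydrogen by chloro gave a 5.2-fold higher number from compound 1 to compound 2 (0.72 log units; beyond the scatter). The same exchange of hydrogen for chloro on this ring therefore has no single direction across these compounds, and a step measured at one place on the ring did not carry over to this one. The data shown offer no measurement that would explain the reversal.

The compounds shown carry the entering chloro only together with the chloro already present, so they leave open whether the lower number belongs to this place alone or depends on both chloro groups being on the ring. They also leave open whether fluoro, methoxy or an amine at this place would move the number in the same direction, and whether the same chloro would do so with phenyl in place of methyl, as in compound 3.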